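The source may report more compounds than this note shows. Statements on the series, on what has been measured and on what is new or still open speak of the compounds shown alone.

Compound 1 `CCCCCCCCc1cc2cn(COCCO)c(O)nc-2n1`: in a functional assay on HEL cells (Homo sapiens), read by microscopy (a lower number here means that less compound is tolerated, a higher number that more compound is tolerated), compound 1 gives 80000 nM.
Compound 2 `CCCCCCCCCc1cc2cn(COCCO)c(=O)nc2o1`: in this assay compound 2 gives only a limit of the assay, >= 16000 nM.
Compound 3 `CCCCCc1cc2cn(COCCO)c(=O)nc2o1`: in this assay compound 3 gives only a limit of the assay, > 400000 nM.

Compounds 2 and 3 share a core and differ by hydrogen in place of butyl on a saturated chain carbon, five bonds along the chain from an aromatic carbon. The step that the two limits leave unreadable from compound 2 to compound 3 cannot be read, since compound 2 sits at the limit of >= 16000 nM in this assay, at which 1 of the 3 values shown sits, and compound 3 at the limit of > 400000 nM in this assay, at which 1 of the 3 values shown sits. Compound 1 is the only one of the three with a number rather than a limit; how its core differs from that of compound 2 is not broken down here.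

Compound 4 `CCCCc1cc2cn(COCCO)c(O)nc-2n1` is not yet measured. It differs from compound 1 by hydrogen in place of butyl on a saturated chain carbon, four bonds along the chain from an aromatic carbon, the same kind of change as between compounds 2 and 3, though the place differs: four bonds along the chain from an aromatic carbon rather than five. Shortening the chain is expected to make compound 4 more tolerated than compound 1, a step of about a 5.0-fold higher number from compound 1 to compound 4 (0.70 log units; beyond the scatter). This rests on compound 3, whose shorter chain leaves it at the limit of > 400000 nM in this assay, at which 1 of the 3 values shown sits. Compound 4 is therefore estimated at 400000 nM, with a likely range from 100000 nM to 1600000 nM.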

Compound 4, minimum cytotoxic concentration: > 400000 nM
Compound 4: only a limit was reported (the forecaster's own chance of this, stated with the estimate: 60%); the middle value lies on the limit itself.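

Where the step can be read, hydrogen in place of butyl gives an at least 5.0-fold higher number from compound 1 to compound 4 (0.69 log units; beyond the scatter) in this assay, so shortening the chain raises the tolerated concentration on this core. On the other core, compound 3 gives > 400000 nM in this assay, which is only a limit of the assay, and the step from compound 2 to compound 3 cannot be read. The two cores therefore point the same way without conflict, but they do not show that the change has the same size on both, and its place on the chain also differs.

On these data alone, it remains open how a hexyl chain would read on either core. Also open, as far as these compounds go, is how a chain ending in an amine or a carboxylic acid would behave.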